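Aryl groups in place of the chloropropyl chain

A few compounds are considered here, and "the series" means these few. Any claim that something is new, unique, unknown or untested is made for them only; others in the source may bear on it.

Compound 3 `O=C1O[C@H]([C@@H](O)Cn2cc(CCCCl)nn2)C(OCc2ccccc2)=C1OCc1ccccc1` is the anchor of this note. In a functional assay on HCT-116 cells (Homo sapiens) for antiproliferative activity, read by MTT assay, with a stated time of 72 h (a lower number here means a stronger inhibitor, a higher number a weaker inhibitor), compound 3 gives 36100 nM. Compound 1 `O=C1O[C@H]([C@@H](O)Cn2cc(-c3cc(F)cc(F)c3)nn2)C(OCc2ccccc2)=C1OCc1ccccc1` gives 48200 nM, and the two values sit within the scatter of each other, a 1.3-fold lower number from compound 1 to compound 3 (0.13 log units; within the scatter). Compound 2 `COc1ccc(-c2cn(C[C@H](O)[C@H]3OC(=O)C(OCc4ccccc4)=C3OCc3ccccc3)nn2)cc1` returns only a limit in this assay, > 100000 nM, so the limit of > 100000 nM in this assay, at which 1 of the 3 values shown sits, is all that can be said of it; the step of an at least 2.7-fold lower number from compound 2 to compound 3 (0.44 log units; beyond the scatter) is therefore at least modest. Among the two numbers shown, compound 3 holds the lower one, with compound 1 nearest.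

Compound 4 `O=C1O[C@H]([C@@H](O)Cn2cc(-c3ccc(Br)cc3)nn2)C(OCc2ccccc2)=C1OCc1ccccc1` is not yet measured. It differs from compound 3 by 4-bromophenyl in place of 3-chloropropyl on an aromatic carbon. The measured steps that bear on this are the two in which an aryl group stands where the chain stands in compound 3: the step to compound 1 is flat within the scatter, while the step to compound 2 is at least modest and runs toward weaker inhibition. A 4-bromophenyl group is expected to behave more like the 3,5-difluorophenyl group of compound 1 than like the 4-methoxyphenyl group of compound 2, so a small rise toward a weaker inhibitor is expected, a 1.7-fold higher number from compound 3 to compound 4 (0.22 log units; within the scatter). For compound 4 in this assay the estimate is 60000 nM, between 30000 nM and 150000 nM.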

Compound 4, half-maximal inhibitory concentration: 9420 nM
Estimate against measurement, compound 4: 6.4-fold (0.80 log units) above; the whole stated range lies above it.
By their numbers in this assay, from the lowest: compound 4; then compounds 3 and 1 (each within the scatter of the next). At a limit, above all of these: compound 2.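

In this assay, for the compounds shown here, 4-bromophenyl is the first group on this aromatic carbon to separate from 3-chloropropyl toward a stronger inhibitor beyond the scatter, with a 3.8-fold lower number from compound 3 to compound 4 (0.58 log units; beyond the scatter), so replacing the chain with an aryl group is not limited to a flat or weakening result. The aryl groups also differ clearly from one another, with a 5.1-fold lower number from compound 1 to compound 4 (0.71 log units; beyond the scatter) and an at least 10-fold lower number from compound 2 to compound 4 (1.02 log units; beyond the scatter), which shows that the substituents on the phenyl ring, rather than the presence of an aryl group alone, decide the outcome at this position among these compounds. Compound 2 gives only a limit, so the step from it is a bound and not a measured size: the limit of > 100000 nM in this assay, at which 1 of the 4 values shown sits.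

As far as these compounds go, whether the gain belongs to bromo itself or to its place on the phenyl ring remains open, and an unsubstituted phenyl, a 4-chlorophenyl or a 3-bromophenyl group would help to separate those readings. From the compounds shown here alone, it is equally open whether a longer chain, or an amine or a carboxylic acid at the end of the 3-chloropropyl chain, would keep the number of compound 3 or move it.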